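Adding a Methyl Group to the Phenoxy Ring

This account rests on a few compounds, and the source may have more. Where it says the series, first, only, none or still open, it means among the compounds named here.

Values from a functional assay on PC-3 cells (Homo sapiens) for antiproliferative activity, read by MTT assay, with a stated time of 48 h (a higher number here means a weaker inhibitor of growth, a lower number a stronger inhibitor of growth), follow
- compound 1 `Cc1ccc(-c2cnc(N(Cc3ccc(C(=O)NO)cc3)CC(C)C)s2)cc1` gives 9340 nM
- compound 2 `Cc1ccc(-c2cnc(N(CCCCOc3ccccc3)Cc3ccc(C(=O)NO)cc3)s2)cc1` gives 10300 nM

Compound 2 stands level with compound 1, and the two values lie within the usual scatter of each other. Compound 3 `Cc1ccc(OCCCCN(Cc2ccc(C(=O)NO)cc2)c2ncc(-c3ccc(C)cc3)s2)cc1` is compound 2 with one small change, (methyl in place of hydrogen on an aromatic carbon). This is methyl in place of hydrogen on an aromatic carbon, turning phenoxy into 4-methylphenoxy. Within the data shown here, no measured pair tests this exact change. Among the measured compounds shown here, the one measured step swaps a whole group, 3-phenoxypropyl in place of isopropyl, and shows a 1.1-fold higher number from compound 1 to compound 2 (0.04 log units; within the scatter) with no shift beyond the scatter. A far smaller edit is therefore expected to cause no step beyond the scatter in this assay in either direction. The estimate is a 1.1-fold lower number from compound 2 to compound 3 (0.04 log units; within the scatter) and so no real change is expected. Compound 3 is estimated at 9500 nM with an expected range from 5000 nM to 18000 nM in this measurement.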

Compound 3, concentration for 50% growth inhibition: 1220 nM
Estimate against measurement, compound 3: 7.8-fold (0.89 log units) above; measured number outside the range, below it.
By their numbers in this assay, from the lowest: compound 3; then compounds 1 and 2 (each within the scatter of the next).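

In this assay the phenoxy end of the side chain proves sensitive to a very small edit: a single methyl, one carbon para to a large group, gives an 8.4-fold lower number from compound 2 to compound 3 (0.93 log units; beyond the scatter) and so counts for more here than the whole side-chain swap that separated compound 1 from compound 2. The 3-(4-methylphenoxy)propyl group also clearly improves on isopropyl, with a 7.7-fold lower number from compound 1 to compound 3 (0.88 log units; beyond the scatter) as the step, so the unsubstituted phenoxy chain brought no such gain but the methylated one does. Nothing available here accounts for this jump.

Still open, as far as these compounds go, is whether the gain is specific to methyl or would also appear with another group at this place, such as ethyl, methoxy or a chlorine atom. The compounds shown also leave unsettled whether a methyl elsewhere on this ring would act the same way.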